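The compounds below may be only part of what the source reports. "The series", "measured", "known", "first", "only" and "open" are said of these compounds alone.

Of the compounds shown here, three have been tested in an ADME assay on HEK293 cells (Homo sapiens) for cytotoxicity, read by resazurin assay, with a stated time of 72 h; on this read-out lower numbers stand for higher toxicity in this test and higher numbers for lower toxicity in this test; a fourth has not.

Compound 1, `CCc1cccc(CNC(=O)c2nc3ccc(F)c(COCc4ccc(C(=O)O)cc4)c3c(=O)[nH]2)c1`, gives > 20000 nM, which is a limit of the assay rather than a number.
Compound 2, `CCc1cccc(CNC(=O)c2nc3ccc(Cl)c(COCc4ccc(C(=O)O)cc4)c3c(=O)[nH]2)c1`, gives > 20000 nM, also a limit.
Compound 3, `CCc1cccc(CNC(=O)c2nc3c(F)ccc(COCc4ccc(C(=O)O)cc4)c3c(=O)[nH]2)c1`, gives > 20000 nM, again a limit.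

Compound 2 differs from compound 1 by chloro in place of fluoro on an aromatic carbon, and the step that the two limits leave unreadable from compound 1 to compound 2 cannot be sized because of the limit of > 20000 nM in this assay, at which 3 of the 3 values shown sit. Compound 3 has the same atoms as compound 1, joined differently; the difference between the two cores is not broken down here. Compound 4, `CCc1cccc(CNC(=O)c2nc3c(Cl)ccc(COCc4ccc(C(=O)O)cc4)c3c(=O)[nH]2)c1`, awaits measurement in this assay. It differs from compound 3 by chloro in place of fluoro on an aromatic carbon, the same kind of change as from compound 1 to compound 2, though at a different place: here ortho to a fused ring and para to a ((4-carboxybenzyl)oxy)methyl group, there ortho to a ((4-carboxybenzyl)oxy)methyl group and para to a fused ring. The step from compound 3 to compound 4 is expected to be a step that the limit leaves unreadable from compound 3 to compound 4, resting on the observation that every measured compound sits at the limit of > 20000 nM in this assay, at which 3 of the 3 values shown sit. Compound 4 is accordingly expected near 30000 nM, between 15000 nM and 80000 nM, most likely reported again only as a limit.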

Compound 4, half-maximal cytotoxic concentration: > 20000 nM
Compound 4: a limit, no number; the forecaster's own chance of this, stated with the estimate: 85%; the middle value lies beyond the limit too.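

The change from compound 3 to compound 4 gives no readable step, because both results are limits rather than numbers: the limit of > 20000 nM in this assay, at which 4 of the 4 values shown sit.

The compounds shown leave open whether swapping fluoro for chloro changes the result in this assay at all, and at what concentration any of the four would harm these cells.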